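Replacing the chlorophenyl vinyl amide with a quinoline amide

The source may hold more compounds than are shown below. What is called first, only, known or untested is meant among the compounds shown, and "the series" means these compounds.

Measured so far:
Compound 1, `CCCN(CC[C@H]1CC[C@H](NC(=O)/C=C/c2cccc(F)c2)CC1)[C@H]1CCc2nc(N)sc2C1`, gives 9.9 nM in an assay on brain for displacement of a labelled ligand from D(3) dopamine receptor (Rattus norvegicus); on this read-out higher numbers stand for weaker inhibition and lower numbers for stronger inhibition.
Compound 2, `CCCN(CC[C@H]1CC[C@H](NC(=O)/C=C/c2ccc(Cl)cc2)CC1)[C@H]1CCc2nc(N)sc2C1`, gives 2.5 nM in this assay.
Compound 3, `CCCN(CC[C@H]1CC[C@H](NC(=O)c2ccc3ccccc3n2)CC1)[C@H]1CCc2nc(N)sc2C1`, gives 1.6 nM in this assay.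

Among these three numbers compound 2 stands second highest. Its nearest neighbour is compound 3, reached by a 1.6-fold lower number from compound 2 to compound 3 (0.19 log units; within the scatter), a step within the scatter; the furthest is compound 1, from which a 4.0-fold lower number from compound 1 to compound 2 (0.60 log units; beyond the scatter) leads to compound 2, a step beyond the scatter.

Compound 4, `CCCN(CC[C@H]1CC[C@H](NC(=O)c2cccc3ncccc23)CC1)[C@H]1CCc2nc(N)sc2C1`, arises from compound 2 by one change: quinolin-5-yl in place of 2-(4-chlorophenyl)ethenyl on a carbonyl carbon. Among the measured compounds shown here, the only measured step that bears on it is the one where the same chain was swapped for an attached quinoline, a 1.6-fold lower number from compound 2 to compound 3 (0.19 log units; within the scatter), which stayed within the scatter, while a 6.2-fold lower number from compound 1 to compound 3 (0.79 log units; beyond the scatter) shows the quinoline amide beating the fluorophenyl chain. Quinolin-5-yl is attached through a different ring carbon than quinolin-2-yl, and no measured pair shows that change, so the expectation is a small step, probably within the scatter, leaning toward a slightly higher number. Compound 4 is therefore estimated at 4 nM, between 1.2 nM and 14 nM, which means an expected step of a 1.6-fold higher number from compound 2 to compound 4 (0.20 log units; within the scatter).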

Compound 4, inhibition constant: 1.6 nM
Compound 4: middle estimate off by 2.5-fold (0.40 log units), on the high side; the range from low to high includes it.
By their numbers in this assay, from the lowest: compounds 3, 4 and 2 (each within the scatter of the next); then compound 1.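

In this assay, among the compounds shown here, moving the attachment from quinolin-2-yl to quinolin-5-yl on the carbonyl carbon gives no change at the digits printed from compound 3 to compound 4 (within the scatter) and so adds what no earlier pair could show: at this position, these two attachment points of the quinoline read alike. The quinolin-5-yl amide also stays level with the chlorophenyl chain, with a 1.6-fold lower number from compound 2 to compound 4 (0.19 log units; within the scatter), and it repeats the drop in number that quinolin-2-yl gave against the fluorophenyl chain, with a 6.2-fold lower number from compound 1 to compound 4 (0.79 log units; beyond the scatter). No measurement at hand explains why the two attachment points read alike.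

On these data alone, whether the ring nitrogen matters stays open, and an all-carbon naphthalen-2-yl amide would test that. Also open, as far as these compounds go, is how an amine or a carboxylic acid on the quinoline, or a longer chain on the carbonyl carbon, would read.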